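The compounds below may be only part of what the source reports. "The series", "measured", "known", "first", "only" and "open" are said of these compounds alone.

Within the data shown here, compound 1 `NC(=O)c1cccc(Cn2cc(-c3ccc4cn[nH]c4c3)ccc2=O)c1` is the only member of this small set with a measured number: in an assay for inhibition of MAP kinase-interacting serine/threonine-protein kinase 2 (Homo sapiens), read by luminescence and ADP-Glo, with a stated time of 2 h (on this read-out lower numbers stand for stronger inhibition and higher numbers for weaker inhibition), compound 1 gives 106 nM. Among the measured compounds shown here, compound 2 `O=c1ccc(-c2ccc3cc[nH]c3c2)cn1Cc1ccccc1` is the other compound that has been tested, and in this assay compound 2 reaches only the limit of > 2000 nM, which is a boundary of the assay rather than a number; it differs from compound 1 in more than one place, so the two values show only that compound 1 sits at a measurable value and compound 2 does not (the limit of > 2000 nM in this assay, at which 1 of the 2 values shown sits). For the measured compounds named here, no pair differing in a single place has been measured.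

Compound 3 `O=c1ccc(-c2ccc3cn[nH]c3c2)cn1Cc1cccc(C(F)(F)F)c1` is the next compound to be examined. It differs from compound 1 by trifluoromethyl in place of carbamoyl on an aromatic carbon, on an aromatic carbon of a six-membered aromatic ring of carbon only, meta to a large group. Since compound 2, which also lacks the carbamoyl, reports only a limit, compound 3 is expected to lose potency, with a step of a 4.7-fold higher number from compound 1 to compound 3 (0.67 log units; beyond the scatter) in this assay. Compound 3 is accordingly estimated at 500 nM, within a range of 150 nM to 2000 nM.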

Compound 3, half-maximal inhibitory concentration: 32 nM
Beside the measured number, compound 3's estimate is 16-fold (1.19 log units) above it; the measured number lies below the stated range.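

Replacing carbamoyl with trifluoromethyl on this aromatic carbon, with the rest of compound 1 unchanged, gives a 3.3-fold lower number from compound 1 to compound 3 (0.52 log units; beyond the scatter) in this assay. The carbamoyl, with its hydrogen-bond donor and acceptor, is therefore not required here for a measurable value on this core, and a group with neither is tolerated, with a modest gain. Compound 2 also lacks the carbamoyl, but its value remains a limit rather than a number and it differs from compound 3 in more than one place, so it cannot be set against this step: the limit of > 2000 nM in this assay, at which 1 of the 3 values shown sits.

This single step does not separate what losing the carbamoyl contributes from what adding the trifluoromethyl contributes, since neither a plain hydrogen nor any other group is shown on this carbon. As far as these compounds go, how a nitrile, a carboxylic acid or a methoxy group would read on the same aromatic carbon, and whether the same swap would give a similar step on a different core, remains open.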